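Amide aryl exchange in compound 1: expected inhibition shift

A few compounds are considered here, and "the series" means these few. Any claim that something is new, unique, unknown or untested is made for them only; others in the source may bear on it.

Measured so far:
- compound 1 `O=C(Nc1ccc(Sc2nc3ccccc3s2)c(Cl)c1)c1cc(Br)cc(Br)c1O` gives 4200 nM in an assay for inhibition of HSP60/HSP10 (Homo sapiens), with a stated time of 60 min; on this read-out higher numbers stand for weaker inhibition and lower numbers for stronger inhibition
- compound 3 `O=C(Nc1ccc(Sc2nc3ccccc3s2)cc1)c1cc(Br)cc(Br)c1O` gives 4700 nM in this assay
- compound 2 `COc1ccccc1C(=O)Nc1ccccc1` reports only a limit in this assay, > 100000 nM

Among the two numbers in this assay, compound 1 holds the lower one; its nearest neighbour is compound 3, and the step of a 1.1-fold higher number from compound 1 to compound 3 (0.05 log units; within the scatter) is within the scatter, so the two cannot be ordered. The limit of compound 2 sits at the limit of > 100000 nM in this assay, at which 1 of the 3 values shown sits, and is a limit, not a number.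

Compound 4 `COc1ccc(Br)cc1C(=O)Nc1ccc(Sc2nc3ccccc3s2)c(Cl)c1` is not yet measured. It differs from compound 1 by 5-bromo-2-methoxyphenyl in place of 3,5-dibromo-2-hydroxyphenyl on a carbonyl carbon. For the measured compounds named here, only one measured step exists, a 1.1-fold higher number from compound 1 to compound 3 (0.05 log units; within the scatter), and it alters a chloro on the core rather than the amide aryl, so it says little about the present change. Compound 2 also carries a methoxy amide aryl, but it lacks the core shared by compound 1 and compound 3, so its limit bears on compound 4 only loosely.

Given the loss of the hydroxyl and of one bromine, compound 4 is expected to show a weaker result, a step of a 4.8-fold higher number from compound 1 to compound 4 (0.68 log units; beyond the scatter). The estimate for compound 4 in this assay is 20000 nM, with a range from 5000 nM to 80000 nM.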

Compound 4, half-maximal inhibitory concentration: > 100000 nM
Compound 4 gave a limit, no number; the forecaster's own chance of this, stated with the estimate: 30%; at least 5.0-fold (0.69 log units) between middle value and limit.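

In this assay compound 4 gives > 100000 nM, which is a limit and not a number. For the compounds shown here, the amide aryl position is far less tolerant than the earlier data could show: the only prior step, at the chloro on the core, was a 1.1-fold higher number from compound 1 to compound 3 (0.05 log units; within the scatter), whereas 5-bromo-2-methoxyphenyl in place of 3,5-dibromo-2-hydroxyphenyl on the carbonyl carbon gives an at least 23-fold higher number from compound 1 to compound 4 (1.37 log units; beyond the scatter). Keeping the core of compound 1 is therefore not enough on its own to give a number in this assay: the limit of > 100000 nM in this assay, at which 2 of the 4 values shown sit.

The change makes two edits at once, exchanging the hydroxyl for a methoxy and removing one bromine, and the compounds shown do not separate them, so it remains open which edit accounts for the step, or whether both are needed. Also open, from the compounds shown here alone, is how this position responds to other groups in place of the hydroxyl, such as an amine or a carboxylic acid, and whether any of them retains a measurable value in this assay.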